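From methylsulfanyl to methoxy in compound 1

This account rests on a few compounds, and the source may have more. Where it says the series, first, only, none or still open, it means among the compounds named here.

- Compound 1 `COc1cc(-c2ocnc2-c2cc(Br)c(OC)c(OC)c2)ccc1SC`: 2480 nM
- Compound 2 `COc1cc(-c2ocnc2-c2cc(OC)c(OC)c(OC)c2)ccc1SC`: 600 nM
- Compound 3 `COc1ccc(-c2c(-c3cc(OC)c(SC)c(OC)c3)ncn2C)cc1O`: 1630 nM
- Compound 4 `COc1ccc(-c2ocnc2-c2cc(Br)c(OC)c(OC)c2)cc1OC`: not yet measured

All of these numbers come from a functional assay on MCF7 cells (Homo sapiens) for cytotoxicity, read by MTT assay, with a stated time of 48 h; a higher number here means a weaker inhibitor, a lower number a stronger inhibitor. Compound 1 stands at the high end of the three measured numbers, and compound 3 lies within the usual scatter of it. Compound 2 has the smallest number of the three.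

Compound 4 keeps the bromo group and differs from compound 1 in one group: methoxy in place of methylsulfanyl on an aromatic carbon. This is methoxy in place of methylsulfanyl on an aromatic carbon, ortho to a methoxy group and para to a large group.

Among the measured compounds shown here, no measured pair shows this swap on its own. For the measured compounds named here, the only measured step, a 4.1-fold lower number from compound 1 to compound 2 (0.62 log units; beyond the scatter), replaces bromo rather than methylsulfanyl. It shows how far one small swap can move the number in this series, but not which way this swap will go. No step beyond the scatter is therefore expected in this assay, although a shift of similar size in either direction remains possible. The estimated step is a 1.2-fold higher number from compound 1 to compound 4 (0.08 log units; within the scatter). Compound 4 is expected at about 3000 nM, with an estimated range from 900 nM to 9000 nM.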

Compound 4, half-maximal inhibitory concentration: 6100 nM
Estimate against measurement, compound 4: 2.0-fold (0.31 log units) below; the range from low to high includes it.
By their numbers in this assay, from the lowest: compound 2; then compounds 3 and 1 (each within the scatter of the next); then compound 4.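

Placing methoxy in place of methylsulfanyl on this aromatic carbon, ortho to a methoxy group and para to a large group, gives in this assay a step of a 2.5-fold higher number from compound 1 to compound 4 (0.39 log units; beyond the scatter), so this position responds to the change even though both groups have the same number of heavy atoms and hydrogen-bond acceptors. The change replaces sulfur with oxygen in a group of otherwise the same make-up, and with the bromo group kept in place, the lower number goes with methylsulfanyl. No measurement here explains why this exchange moves the number in this direction.

Only these two groups are shown at this position, so how an amine or a longer chain such as ethoxy would behave there remains open. From the compounds shown here alone, it is also open whether the same exchange would move the number in the same direction if the bromo group were replaced by methoxy, as it is in compound 2.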